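Cyano for trifluoromethyl: the step to compound 4

This account rests on a few compounds, and the source may have more. Where it says the series, first, only, none or still open, it means among the compounds named here.

compound 1 `COc1cccc(Cc2cc(C(C)C)nn(CC(=O)Nc3ccc(Br)cc3)c2=O)c1` — 17400 nM
compound 2 `COc1ccc(Cc2cc(-c3ccc(OC)cc3)nn(CC(=O)Nc3ccc(Br)cc3)c2=O)cc1` — > 50000 nM
compound 3 `Cc1cc(Cc2ccc(C(F)(F)F)cc2)c(=O)n(CC(=O)Nc2ccc(Br)cc2)n1` — > 50000 nM

For the measured compounds named here, in an assay on HL-60 cells for agonist activity at N-formyl peptide receptor 3 (Homo sapiens), read by calcium flux (a lower number here means that less compound is needed, a higher number that more compound is needed for the effect), compound 1 gives 17400 nM, the only number among the three. For compound 2 the reading is a limit of this assay, > 50000 nM. Compound 3 likewise sits at a limit, > 50000 nM, so its standing is known only as the limit of > 50000 nM in this assay, at which 2 of the 3 values shown sit. Compound 4 `Cc1cc(Cc2ccc(C#N)cc2)c(=O)n(CC(=O)Nc2ccc(Br)cc2)n1` differs from compound 3 by cyano in place of trifluoromethyl on an aromatic carbon, in words cyano in place of trifluoromethyl on an aromatic carbon. Going by the values given here, no measured pair shows this change, so no step size is known, and nothing among the three compounds points to the change bringing the activity into the measurable range. The expectation for compound 4 is therefore another limit, 50000 nM (range 20000 nM to 150000 nM). This means an expected step of a number no higher from compound 3 to compound 4 (the limit leaves the size open), none beyond the scatter.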

Compound 4, half-maximal effective concentration: > 50000 nM
Compound 4 ended at the assay's limit; the forecaster's own chance of this, stated with the estimate: 75%; the middle value lies on the limit itself.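

Compound 3 and compound 4 both sit at a limit of this assay, so no step between them can be read: the limit of > 50000 nM in this assay, at which 3 of the 4 values shown sit.

The compounds shown leave open how 4-(trifluoromethyl)phenyl and 4-cyanophenyl compare on the shared core.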